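The compounds below may be only part of what the source reports. "The series", "measured", "known", "first", "only" and "open" are said of these compounds alone.

Compound 1 `Oc1ccccc1CNc1ccc(N2CCCC2)cc1` has no single number to stand on: in a functional assay on Jurkat cells (Homo sapiens) for activation, with a stated time of 24 h (a higher number here means that more compound is needed for the effect, a lower number that less compound is needed), compound 1 is "not active" (no number reported), so it cannot be placed on a scale of half-maximal effective concentrations. Compound 2 `Oc1ccccc1CNc1ccc(-c2ccc(-c3ccccc3)cc2)cc1` carries no number either, as in this assay compound 2 is "not active" (no number reported). The only numbered entry in the series is compound 3 `CCOc1ccc(-c2ccc(NCc3ccccc3O)cc2)cc1`, which in this assay gives 520 nM. Compound 4 `Oc1ccccc1CNc1ccc(-c2cccc(F)c2)cc1` is still to be measured.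

Relative to compound 1 the change is 3-fluorophenyl in place of pyrrolidin-1-yl on an aromatic carbon. Among the measured compounds shown here, no step between measured compounds is available for this change, and because compound 1 is "not active" (no number reported) the step from compound 1 to compound 4 cannot be sized against the scatter at all. The expectation is that compound 4 moves from no reported activity to a measurable half-maximal effective concentration, that is, a step in the direction of less compound needed, though an outcome with no number, as seen for compound 2 with "not active" (no number reported), remains a real possibility.

Compound 4 is expected to give 1500 nM in this assay, within a range from 300 nM to 10000 nM. This estimate rests on compound 3, which gives 520 nM in this assay with a single aryl group in the same place, and is widened toward weaker values by compound 2, which is "not active" (no number reported) in this assay.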

Compound 4, half-maximal effective concentration: 2020 nM
Beside the measured number, compound 4's estimate is 1.3-fold (0.13 log units) below it, and the stated range covers the measured number.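

No step can be read from compound 1 to compound 4: in this assay compound 1 is "not active" (no number reported) and so offers no number to measure the change against. The compounds shown leave open how far 3-fluorophenyl in place of pyrrolidin-1-yl shifts the half-maximal effective concentration. No measured evidence bears on this result.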